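The source may hold more compounds than are shown below. What is called first, only, known or untested is meant among the compounds shown, and "the series" means these compounds.

Compound 1 `CC(C)(C)c1ccc(S(=O)(=O)N[C@H]2CCN(Cc3cc4cc[nH]cc-4n3)C2=O)cc1` is the starting point of this small set. In an assay on isolated protein for inhibition of coagulation factor X (Oryctolagus cuniculus), tested at 1 uM (on this read-out lower numbers stand for less inhibition and higher numbers for more inhibition at the one concentration tested (going by the name of the read-out)), compound 1 gives 57%. Compound 2 `CC(C)(C)c1ccc(S(=O)(=O)N[C@H]2CCN(CCNc3ccncc3)C2=O)cc1` carries one change relative to compound 1: a group of 8 heavy atoms (6 carbon, 2 nitrogen; one six-membered aromatic ring with 1 hetero atom) in place of a group of 9 heavy atoms (7 carbon, 2 nitrogen; one five-membered aromatic ring with 1 hetero atom, one six-membered aromatic ring with 1 hetero atom), on a saturated chain carbon bound to an amide-type nitrogen in a ring. That change made a step of a number 43 percentage points lower from compound 1 to compound 2 (beyond the scatter), and in this assay compound 2 gives 14%. Compound 3 `O=C1[C@@H](NS(=O)(=O)c2nc3cc(Cl)ccc3[nH]2)CCN1Cc1cc2cc[nH]cc-2n1` differs from compound 1 in another place, namely (5-chloro-1H-benzimidazol-2-yl in place of 4-(tert-butyl)phenyl on a sulfonyl sulfur), which produced a step of a number 36 percentage points lower from compound 1 to compound 3 (beyond the scatter); in this assay compound 3 gives 21%. Compound 4 `O=C1[C@@H](NS(=O)(=O)c2nc3cc(Cl)ccc3[nH]2)CCN1CCNc1ccncc1` has not been measured yet. Within the data shown here, it arises from compound 3 by a group of 8 heavy atoms (6 carbon, 2 nitrogen; one six-membered aromatic ring with 1 hetero atom) in place of a group of 9 heavy atoms (7 carbon, 2 nitrogen; one five-membered aromatic ring with 1 hetero atom, one six-membered aromatic ring with 1 hetero atom), on a saturated chain carbon bound to an amide-type nitrogen in a ring, and since the two place descriptions match word for word, this is the same change as the one from compound 1 to compound 2. Measured once, that change gave a number 43 percentage points lower from compound 1 to compound 2 (beyond the scatter). Starting from the lower value of compound 3, a step of a number 16 percentage points lower from compound 3 to compound 4 (beyond the scatter) is expected, smaller than the earlier one only since the read-out cannot fall far further. Compound 4 is therefore estimated at 5%, between 0% and 15%.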

Compound 4, a percentage reported as inhibition, at one concentration (the size of the read-out at that concentration, not a potency): 29%
The estimate for compound 4 lay 24 percentage points below the measured number, outside the stated range (above it).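

On the core of compound 3, bringing in ((pyridin-4-yl)amino)methyl on a saturated chain carbon bound to an amide-type nitrogen in a ring gave a number 8 percentage points higher from compound 3 to compound 4 (within the scatter), so in this assay this change has no effect that can be told from the scatter on this core. Set beside the earlier step, the same change did not behave alike on the two cores: the same change on two cores in this assay, a number 43 percentage points lower (beyond the scatter) from compound 1 to compound 2 and a number 8 percentage points higher (within the scatter) from compound 3 to compound 4, 51 percentage points apart, beyond the scatter of two such steps This shows that the size of the step on one core is a poor guide to its size on the other, but it does not show why the cores differ, and two pairs give no rule for any further core.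

Still open, as far as these compounds go, is whether a third group on the sulfonyl sulfur, such as a plain phenyl or a 4-chlorophenyl, would follow the pattern of compound 1 and compound 2 or that of compound 3 and compound 4. Also open, from the compounds shown here alone, is how a longer chain, or a simple amine in place of the pyridine ring, would fare on either core.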